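The compounds below may be only part of what the source reports. "The series", "measured", "known", "first", "only" and "open" are said of these compounds alone.

Measured so far in a functional assay on ECa-109 cells (Homo sapiens) for cytotoxicity, read by MTT assay, with a stated time of 72 h (on this read-out higher numbers stand for weaker inhibition and lower numbers for stronger inhibition), are two compounds, each reported only as a limit of the assay and not as a number:

- compound 1 (`Cc1cc(NC(C)C)nc(SCc2nc3ccccc3[nH]2)n1`) gives > 100000 nM as its limit
- compound 2 (`Cc1cc(N2CCNCC2)nc(SCc2nc3ccccc3[nH]2)n1`) gives > 100000 nM as its limit

Compound 1 therefore has no exact place on the scale. Going by the values given here, it sits at the same limit as the only other compound measured, as the limit of > 100000 nM in this assay, at which 2 of the 2 values shown sit, records.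

Compound 3 (`COc1ccccc1Nc1cc(C)nc(SCc2nc3ccccc3[nH]2)n1`) keeps the core of compound 1 and alters one group: 2-methoxyphenyl in place of isopropyl on a nitrogen on an aromatic ring. In short, isopropylamino gives way to (2-methoxyphenyl)amino.

One measured step changes that same isopropylamino group: a step that the two limits leave unreadable from compound 1 to compound 2. It has no readable size, so it offers neither a size nor a direction to carry over. Compound 1 and compound 2 both rest at the limit of > 100000 nM in this assay, at which 2 of the 2 values shown sit, so the likeliest expectation is that compound 3 will also be reported only as a limit. A real number would be expected to fall not far on the stronger side of that limit.

The expected change is an at least 1.4-fold lower number from compound 1 to compound 3 (0.15 log units; that floor lies within the scatter), a rough estimate. The estimate for compound 3 is 70000 nM (expected range 15000 nM to 150000 nM), and little firm data stands behind it.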

Compound 3, half-maximal inhibitory concentration: 34400 nM
Estimate against measurement, compound 3: 2.0-fold (0.31 log units) above, within the range that was stated.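

In this assay, putting (2-methoxyphenyl)amino where isopropylamino stood gives an at least 2.9-fold lower number from compound 1 to compound 3 (0.46 log units; beyond the scatter), which shows that this position on the shared core can take a change that brings a measurable effect on the cells. Putting the same group where piperazin-1-yl stood gives an at least 2.9-fold lower number from compound 2 to compound 3 (0.46 log units; beyond the scatter), so two different starting groups lead to the same conclusion, and both sizes are only floors, since the true values of the starting compounds lie somewhere past the limit. The step between compound 1 and compound 2 still cannot be read, as both rest at the same limit of the assay: the limit of > 100000 nM in this assay, at which 2 of the 3 values shown sit.

The compounds shown cannot separate the contribution of the aromatic ring from that of the methoxy group it carries, and a plain phenyl on the same nitrogen would be the direct test of that question. As far as these compounds go, it also stays open whether the ring must sit directly on that nitrogen, as a benzyl group would place it one carbon further out, and how far the value of compound 3 could move with other groups on the ring, such as a chlorine or a hydroxyl.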